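Changing the aromatic-nitrogen substituent: a cytotoxicity outlook

This account rests on a few compounds, and the source may have more. Where it says the series, first, only, none or still open, it means among the compounds named here.

Compound 1, `Cc1c(CNCCN2CCN(C)CC2)c(-c2ccccc2)nn1-c1ccc(F)cc1`: in an ADME assay on Huh-7 cells (Homo sapiens) for cytotoxicity (on this read-out lower numbers stand for higher toxicity in this test and higher numbers for lower toxicity in this test), compound 1 reaches only the assay limit of > 20000 nM.
Compound 2, `Cc1ccccc1-c1nn(-c2ccc(OC(F)(F)F)cc2)cc1CNCCN1CCN(C)CC1`: in this assay compound 2 gives 17000 nM.

Among the compounds with values here, compound 2 thus holds the only measured number in this set; the other value is a limit, (the limit of > 20000 nM in this assay, at which 1 of the 2 values shown sits). Compound 3, `Cc1ccc(-n2cc(CNCCN3CCN(C)CC3)c(-c3ccccc3C)n2)c(C)c1`, differs from compound 2 by 2,4-dimethylphenyl in place of 4-(trifluoromethoxy)phenyl on an aromatic nitrogen. Within the data shown here, no measured step covers this kind of change, so in this assay the expectation is a shift that stays within the usual scatter, leaning towards lower toxicity. Compound 3 is estimated at 20000 nM, with a range of 8000 nM to 50000 nM. The step this estimate implies is expected to be small, a 1.2-fold higher number from compound 2 to compound 3 (0.07 log units; within the scatter).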

Compound 3, half-maximal cytotoxic concentration: > 20000 nM
Compound 3 gave a limit, no number (the forecaster's own chance of this, stated with the estimate: 50%); the middle value lies on the limit itself.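

On the aromatic nitrogen, 2,4-dimethylphenyl in place of 4-(trifluoromethoxy)phenyl gives in this assay an at least 1.1-fold higher number from compound 2 to compound 3 (0.07 log units; that floor lies within the scatter), so this all-carbon group, with no hydrogen-bond acceptor, does not pull the read-out down. The value of compound 3 is a limit, not a number. The true size of the step cannot be read because the values collect at that ceiling: the limit of > 20000 nM in this assay, at which 2 of the 3 values shown sit.

Still open, going by these compounds, is whether a phenyl group carrying a carboxylic acid or an amine on this nitrogen would bring the number down.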